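Longer Alkyl Chain on Compound 3: Expected Outcome

The compounds below may be only part of what the source reports. "The series", "measured", "known", "first", "only" and "open" are said of these compounds alone.

Three compounds have been measured in a functional assay on THP-1 cells (Homo sapiens) for cytotoxicity, read by MTT assay, with a stated time of 24 h; on this read-out lower numbers stand for stronger inhibition and higher numbers for weaker inhibition:
Compound 1 `CCCCCCCCCCn1cc(Cn2c(C)nc3nc(-c4ccccc4)cc(C(F)(F)F)c3c2=O)nn1` gives 11.3 ug/mL.
Compound 2 `CCc1nc2nc(-c3ccccc3)cc(C(F)(F)F)c2c(=O)n1Cc1cn(CCC(F)(F)C(F)(F)C(F)(F)C(F)(F)C(F)(F)C(F)(F)F)nn1` gives only a limit, > 200 ug/mL.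
Compound 3 `CCc1nc2nc(-c3ccccc3)cc(C(F)(F)F)c2c(=O)n1Cc1cn(CCC(F)(F)C(F)(F)C(F)(F)C(F)(F)C(F)(F)C(F)(F)C(F)(F)C(F)(F)F)nn1` gives only a limit, > 200 ug/mL.

Compound 3 therefore stands at the limit of > 200 ug/mL in this assay, at which 2 of the 3 values shown sit, and no number is known for it. Among the measured compounds shown here, the one step between measured compounds, a step that the two limits leave unreadable from compound 2 to compound 3, concerns the fluorinated chain and cannot be read. For the measured compounds named here, compound 1 and compound 3 differ in two places at once, so their values show only that one gives a number and the other a limit.

Compound 4 `CCCCCCc1nc2nc(-c3ccccc3)cc(C(F)(F)F)c2c(=O)n1Cc1cn(CCC(F)(F)C(F)(F)C(F)(F)C(F)(F)C(F)(F)C(F)(F)C(F)(F)C(F)(F)F)nn1` differs from compound 3 by butyl in place of hydrogen on a saturated chain carbon, two bonds along the chain from an aromatic carbon, which reads as ethyl to hexyl. Going by the values given here, no measured step covers this change, so nothing supports a move in either direction in this assay. Compound 4 is therefore expected to stay near the limit, with an expected step of a number no higher from compound 3 to compound 4 (the limit leaves the size open). The estimate for compound 4 is 200 ug/mL, within 60 ug/mL to 400 ug/mL.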

Compound 4, half-maximal inhibitory concentration: > 200 ug/mL
Compound 4: no number, only a limit (the forecaster's own chance of this, stated with the estimate: 70%); the middle value lies on the limit itself.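

Compound 3 and compound 4 each give only a limit and not a number, so the step between them cannot be read: the limit of > 200 ug/mL in this assay, at which 3 of the 4 values shown sit. The compounds shown leave open whether going from ethyl to hexyl changes this read-out at all.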